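The compounds below may be only part of what the source reports. "The series", "measured", "known", "first", "only" and "open" are said of these compounds alone.

Measured compounds:
- compound 1 `CCCCC(O)CC(=O)O[C@H](CC=C(C)C)C1=CC(=O)c2c(O)ccc(O)c2C1=O`: 45300 nM
- compound 2 `CC(C)=CC[C@@H](OC(=O)CC(O)c1ccccc1)C1=CC(=O)c2c(O)ccc(O)c2C1=O`: 17000 nM
- compound 3 `CC(C)=CC[C@@H](OC(=O)CC(C)(O)c1ccccc1)C1=CC(=O)c2c(O)ccc(O)c2C1=O`: a limit of the assay, > 100000 nM

All numbers come from a functional assay on DU-145 cells (Homo sapiens) for cytotoxicity, read by MTT assay; on this read-out higher numbers stand for weaker inhibition and lower numbers for stronger inhibition. For compound 3 the value is only a limit, the one given by the limit of > 100000 nM in this assay, at which 1 of the 3 values shown sits. The change butyl in place of phenyl on a saturated chain carbon bound to an oxygen on a saturated carbon and a saturated chain carbon has been measured once, as a 2.7-fold higher number from compound 2 to compound 1 (0.43 log units; beyond the scatter). Compound 4 `CCCCC(C)(O)CC(=O)O[C@H](CC=C(C)C)C1=CC(=O)c2c(O)ccc(O)c2C1=O` carries the same kind of change, (butyl in place of phenyl on a saturated chain carbon bound to an oxygen on a saturated carbon and two saturated chain carbons); around the place the carbon is bound to two saturated chain carbons rather than one. The cores differ by methyl in place of hydrogen on a saturated chain carbon bound to an aromatic carbon, an oxygen on a saturated carbon and a saturated chain carbon, a change that gave an at least 5.8-fold higher number from compound 2 to compound 3 (0.76 log units; beyond the scatter). In this assay the expected step is a step that the limit leaves unreadable from compound 3 to compound 4, set beside a 2.7-fold higher number from compound 2 to compound 1 (0.43 log units; beyond the scatter) because compound 3 already sits at the limit of the limit of > 100000 nM in this assay, at which 1 of the 3 values shown sits. Compound 4 is therefore estimated at 200000 nM, most likely reported only as a limit.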

Compound 4, half-maximal inhibitory concentration: 76500 nM
Estimate against measurement, compound 4: 2.6-fold (0.42 log units) above; low and high end bracket the measured number.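

In this assay, butyl in place of phenyl does not carry over unchanged from one core to the other, the new step being an at least 1.3-fold lower number from compound 3 to compound 4 (0.11 log units; that floor lies within the scatter): the same change on two cores in this assay, a 2.7-fold higher number (0.43 log units; beyond the scatter) from compound 2 to compound 1 and an at least 1.3-fold lower number (0.11 log units; that floor lies within the scatter) from compound 3 to compound 4, at least 3.4-fold (0.54 log units) apart, beyond the scatter of two such steps. The added methyl also depends on the core, reading a 1.7-fold higher number from compound 1 to compound 4 (0.23 log units; within the scatter) with butyl in place, while the combined replacement gives a 4.5-fold higher number from compound 2 to compound 4 (0.65 log units; beyond the scatter): the same change on two cores in this assay, an at least 5.8-fold higher number (0.76 log units; beyond the scatter) from compound 2 to compound 3 and a 1.7-fold higher number (0.23 log units; within the scatter) from compound 1 to compound 4, at least 3.4-fold (0.54 log units) apart, beyond the scatter of two such steps. The two changes therefore do not simply add, but the true size of the gaps is not shown, since the value of compound 3 is only a limit: the limit of > 100000 nM in this assay, at which 1 of the 4 values shown sits.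

Going by these compounds, it remains open whether this dependence on the core persists with a longer chain such as octyl or with a cyclohexyl ring at this place. An amine in place of the hydroxy group is also untested here.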